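A hydroxy group added to a compound at the assay limit

A few compounds are considered here, and "the series" means these few. Any claim that something is new, unique, unknown or untested is made for them only; others in the source may bear on it.

Going by the values given here, in an ADME assay on HEK293 cells (Homo sapiens) for cytotoxicity, read by reporter gene assay and resazurin assay, with a stated time of 48 h (on this read-out lower numbers stand for higher toxicity in this test and higher numbers for lower toxicity in this test), compound 1 `O=C(Nc1cccc(Cl)c1)c1cc(Br)cc(Br)c1` gives 53000 nM, the only true number in this small set. Compound 2 `O=C(Nc1ccc(Sc2nc3ccccc3s2)cc1)c1cc(Br)cc(Br)c1` reads > 100000 nM, which is a limit of the assay and not a number. Compound 3 `O=C(Nc1ccc(Sc2nc3ccccc3s2)cc1)c1ccccc1` reads > 100000 nM, which is again a limit. Its exact place on the scale is therefore unknown, and the overall picture is the limit of > 100000 nM in this assay, at which 2 of the 3 values shown sit.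

Compound 4 `O=C(Nc1ccc(Sc2nc3ccccc3s2)cc1)c1ccccc1O` differs from compound 3 by a single change, hydroxy in place of hydrogen on an aromatic carbon, ortho to a large group. Among the compounds with values here, the one measured step in the set is a step that the two limits leave unreadable from compound 2 to compound 3. It concerns another change and has no readable size, so it offers no size to carry over to this one.

The expectation in this assay therefore rests on the starting point, because compound 3 reads > 100000 nM. No step beyond the usual scatter is expected, and any movement would more likely be towards a lower number, since a limit may hide a value far up the scale. The expected step is an at least 1.1-fold lower number from compound 3 to compound 4 (0.04 log units; that floor lies within the scatter). The estimate for compound 4 is 90000 nM, within an estimated range of 30000 nM to 200000 nM, and a further limit would be no surprise.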

Compound 4, half-maximal cytotoxic concentration: 74000 nM
Beside the measured number, compound 4's estimate is 1.2-fold (0.09 log units) above it, within the range that was stated.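

With hydroxy in place of hydrogen on an aromatic carbon, ortho to a large group, compound 4 gives 74000 nM in this assay, a true number on the scale for this core with the benzothiazole-free comparison left aside. Compound 3 reads > 100000 nM, which is a limit of the assay and not a number. The hydroxy change therefore reads as an at least 1.3-fold lower number from compound 3 to compound 4 (0.13 log units; that floor lies within the scatter), and 2-hydroxyphenyl in place of 3,5-dibromophenyl reads as an at least 1.3-fold lower number from compound 2 to compound 4 (0.13 log units; that floor lies within the scatter), and both are only floors within the usual scatter, so this position tolerates the change without a step that can be called real, and the true sizes stay unknown because the starting points are limits: the limit of > 100000 nM in this assay, at which 2 of the 4 values shown sit.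

The step between the two limits, from compound 2 to compound 3, cannot be read. From the compounds shown here alone, whether a methoxy group or an amine on the same aromatic carbon would give a number clearly lower than that of compound 4 remains open, as does the effect of a hydroxy group elsewhere on that six-membered ring.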